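From a Hydroxylated Side Chain to Cyclohexyl

A few compounds are considered here, and "the series" means these few. Any claim that something is new, unique, unknown or untested is made for them only; others in the source may bear on it.

In a physicochemical assay for lipophilicity, read by HPLC, measured as chromatographic lipophilicity, at pH 7.4 (a higher number here means a more lipophilic compound, a lower number a more polar compound), compound 1 (`O=C(C1CCC1)N1N=CCC1c1ccccc1`) reads 4.7 and compound 2 (`CC(C)(CO)C(=O)N1N=CCC1c1ccccc1`) reads 3.4 as the lower of the two numbers. Compound 3 (`O=C(C1CCCCC1)N1N=CCC1c1ccccc1`) carries cyclohexyl in place of 1-(hydroxymethyl)-1-methylethyl on a carbonyl carbon. Going by the values given here, the only measured step bearing on this is large, a number 1.30 log units lower from compound 1 to compound 2 (beyond the scatter) as that same group replaced cyclobutyl. The new change undoes that exchange, though with cyclohexyl rather than cyclobutyl entering, so a large upward move is expected, an estimated a number 1.90 log units higher from compound 2 to compound 3 (beyond the scatter) in this assay on this reasoning. For compound 3 the expected value is 5.3 (estimated range 4.9 to 5.8).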

Compound 3, distribution coefficient: 5.9
Compound 3: middle estimate off by 0.60 log units, on the low side, and the stated range ends below it.
By their numbers in this assay, from the lowest: compound 2; then compound 1; then compound 3.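

In this assay, placing cyclohexyl on the carbonyl carbon in place of 1-(hydroxymethyl)-1-methylethyl gives a number 2.50 log units higher from compound 2 to compound 3 (beyond the scatter). Exchanging cyclobutyl for cyclohexyl gives a number 1.20 log units higher from compound 1 to compound 3 (beyond the scatter), so the read-out at this place also separates two rings of carbon only, not just a ring from the chain bearing the hydroxyl. Nothing at hand accounts for the size of either step. On these data alone, whether cyclopentyl would fall between the two rings remains open, as does where an amine or a carboxylic acid at this place would read.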